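Shifting a fluorine on the pyridyl of an mGlu5 agonist

A few compounds are considered here, and "the series" means these few. Any claim that something is new, unique, unknown or untested is made for them only; others in the source may bear on it.

Measured so far:
- Compound 1, `C[C@@H](NC(=O)c1ccc(C#Cc2ccccc2)cn1)C(C)(C)O`: 43.2%
- Compound 2, `C[C@@H](NC(=O)c1ccc(C#Cc2cc(F)cc(F)c2)cn1)C(C)(C)O`: 37.9%
- Compound 3, `C[C@@H](NC(=O)c1ccc(C#Cc2cccc(F)n2)cn1)C(C)(C)O`: 8.3%

In an ADME assay on HEK293 cells for agonist activity at metabotropic glutamate receptor 5 (Rattus norvegicus), read by fluorescence and calcium flux (a higher number here means a larger maximal response, a lower number a smaller maximal response), compound 3 gives 8.3%, the lowest of the three numbers; compound 2 stands nearest, a number 29.6 percentage points lower from compound 2 to compound 3 (beyond the scatter), and compound 1 furthest, a number 34.9 percentage points lower from compound 1 to compound 3 (beyond the scatter). Both of these steps exchanged a phenyl for the 6-fluoropyridin-2-yl and each lost a large share of the response, whereas a number 5.3 percentage points lower from compound 1 to compound 2 (within the scatter) kept the phenyl and changed little.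

Compound 4, `C[C@@H](NC(=O)c1ccc(C#Cc2cc(F)ccn2)cn1)C(C)(C)O`, has not yet been measured. It differs from compound 3 in one place: 4-fluoropyridin-2-yl in place of 6-fluoropyridin-2-yl on a triple-bonded carbon. Among the compounds with values here, no measured step moves a fluorine within a pyridyl, so none bears directly on this change. What the steps do show is that the pyridyl itself went with the low response of compound 3, and compound 4 keeps a pyridyl. The expectation is therefore a response staying near that of compound 3, with a number 5.7 percentage points higher from compound 3 to compound 4 (within the scatter) expected to lie within the scatter. Compound 4 is estimated to give 14% in this assay, with a range from 3% to 38%.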

Compound 4, largest response reached (reported as efficacy), in percent of the reference or control that the assay uses: 33%
The estimate for compound 4 lay 19 percentage points below the measured number, and the stated range covers the measured number.
By their numbers in this assay, from the lowest: compound 3; then compounds 4, 2 and 1 (each within the scatter of the next, the first and the last beyond it).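

Moving the fluorine alone, with the same atoms joined differently, gives a number 24.7 percentage points higher from compound 3 to compound 4 (beyond the scatter) in this assay and so shows that a pyridyl does not by itself bring a low response, since compound 4 carries one too. The 4-fluoropyridin-2-yl stands level with the 3,5-difluorophenyl at a number 4.9 percentage points lower from compound 2 to compound 4 (within the scatter) but remains short of the plain phenyl at a number 10.2 percentage points lower from compound 1 to compound 4 (beyond the scatter) in the same assay. Nothing available explains why the place of the fluorine matters so much.

The compounds shown leave open how a pyridin-2-yl carrying no fluorine would compare. They also leave open whether a chlorine or a methyl group in place of the fluorine of the 4-fluoropyridin-2-yl would keep the response.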